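This account rests on a few compounds, and the source may have more. Where it says the series, first, only, none or still open, it means among the compounds named here.

Two compounds of this series already have numbers in a functional assay on CHO cells for positive allosteric modulation of metabotropic glutamate receptor 2 (Homo sapiens), with a stated time of 30 min; on this read-out higher numbers stand for larger maximal responses and lower numbers for smaller maximal responses. Compound 1 `CC(C)CCn1ccc(N2CCCC(c3ccccc3)C2)c(C#N)c1=O` gives 231%, and compound 2 `N#Cc1c(N2CCC(c3ccccc3)CC2)ccn(CC2CCC2)c1=O` gives 269%. Compound 2 thus stands highest of the two, and its gap to compound 1 lies beyond the usual scatter of repeated measurements.

Compound 3 `N#Cc1c(N2CCC(c3ccccc3)CC2)ccn(CCCC(F)(F)F)c1=O` has not yet been measured. It differs from compound 2 in a single place: 3,3,3-trifluoropropyl in place of cyclobutyl on a saturated chain carbon bound to an aromatic nitrogen. Among the compounds with values here, no pair of measured compounds shows an exchange of this kind, so there is no precedent to draw on.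

With only the two measured numbers to lean on, the change expected here is a number 19 percentage points lower from compound 2 to compound 3 (beyond the scatter), a modest drop that stays close to the scatter rather than a large move in either direction. On that basis compound 3 is estimated at 250% in this assay, with a range from 180% to 320%.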

Compound 3, largest response reached (Emax), in percent of the reference or control that the assay uses: 302%
Beside the measured number, compound 3's estimate is 52 percentage points below it; low and high end bracket the measured number.
By their numbers in this assay, from the lowest: compound 1; then compound 2; then compound 3.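

In this assay, putting 3,3,3-trifluoropropyl in place of cyclobutyl on a saturated chain carbon bound to an aromatic nitrogen gives a number 33 percentage points higher from compound 2 to compound 3 (beyond the scatter). For this pair, the four-membered ring is therefore not needed for a large maximal response, and an open chain ending in fluorine atoms can reach a higher one. Nothing available here explains why the response rises with this exchange.

The exchange changes the ring to a chain and brings in fluorine at the same time, so this single step cannot separate the two changes; a plain propyl or butyl chain in the same place would help to do so. On these data alone, it also remains open whether 3,3,3-trifluoropropyl would raise the response on the core of compound 1.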